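Side-chain exchanges on a shared core: cytotoxicity notes

This account rests on a few compounds, and the source may have more. Where it says the series, first, only, none or still open, it means among the compounds named here.

Measured so far:
compound 1 `O=C1c2c[n+]([O-])c3ccccc3c2C(=O)c2c1c1ccccc1n2CCCCn1ccnc1`: 130 nM
compound 2 `O=C1c2c[n+]([O-])c3ccccc3c2C(=O)c2c1c1ccccc1n2Cc1cn(CC(O)CO)nn1`: 1110 nM
compound 3 `O=C1c2c[n+]([O-])c3ccccc3c2C(=O)c2c1c1ccccc1n2CCN1CCCC1`: 320 nM

In a functional assay on MCF7 cells (Homo sapiens) for cytotoxicity, read by MTT assay, with a stated time of 72 h (on this read-out higher numbers stand for weaker inhibition and lower numbers for stronger inhibition), compound 1 gives the lowest of the three numbers. Its nearest neighbour is compound 3, at a 2.5-fold higher number from compound 1 to compound 3 (0.39 log units; beyond the scatter), and its furthest is compound 2, at an 8.5-fold higher number from compound 1 to compound 2 (0.93 log units; beyond the scatter); the two steps between the other pair read a 3.5-fold lower number from compound 2 to compound 3 (0.54 log units; beyond the scatter).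

Compound 4 `O=C1c2c[n+]([O-])c3ccccc3c2C(=O)c2c1c1ccccc1n2CCCN1CCC(O)CC1` has not been measured. Against compound 1 the change is 4-hydroxypiperidin-1-yl in place of (1H-imidazol-1-yl)methyl on a saturated chain carbon, three bonds along the chain from an aromatic nitrogen.

Among the measured compounds shown here, two measured steps bear on this. The step from compound 1 to compound 3, a saturated nitrogen ring in place of the imidazolyl chain, was modest and upward. The step from compound 1 to compound 2, which brings in hydroxyl groups, was larger and also upward. Compound 4 brings both a saturated nitrogen ring and a hydroxyl group, so a modest rise in the number, beyond the scatter but well short of the step to compound 2, is expected in this assay.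

The expected step is a 2.7-fold higher number from compound 1 to compound 4 (0.43 log units; beyond the scatter). Compound 4 is therefore estimated at 350 nM, with a range from 150 nM to 900 nM.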

Compound 4, half-maximal inhibitory concentration: 190 nM
Compound 4: middle estimate off by 1.8-fold (0.27 log units), on the high side, and the stated range covers the measured number.
By their numbers in this assay, from the lowest: compounds 1, 4 and 3 (each within the scatter of the next, the first and the last beyond it); then compound 2.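

In this assay, the 3-(4-hydroxypiperidin-1-yl)propyl chain cannot be told apart from the 4-(1H-imidazol-1-yl)butyl chain, the step being a 1.5-fold higher number from compound 1 to compound 4 (0.16 log units; within the scatter), so at this position an aromatic imidazole end is not needed for a number of this order. The same holds against the 2-(pyrrolidin-1-yl)ethyl chain, with a 1.7-fold lower number from compound 3 to compound 4 (0.23 log units; within the scatter), so compound 4 links compound 1 and compound 3 through two steps that each stay within the scatter, even though the direct step between those two lies beyond it. A hydroxyl on the side chain also does not by itself go with the higher number of compound 2, as a 5.8-fold lower number from compound 2 to compound 4 (0.77 log units; beyond the scatter) separates the two clearly, and nothing measured here accounts for any of these steps.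

A plain piperidin-1-yl or a morpholin-4-yl on the same propyl chain would show whether the hydroxyl of compound 4 counts for anything. Chain length and end group also change together in these compounds, so a 4-hydroxypiperidin-1-yl on a butyl chain, or an imidazol-1-yl on a propyl chain, would be needed to pull the two apart.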